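The source may report more compounds than this note shows. Statements on the series, on what has been measured and on what is new or still open speak of the compounds shown alone.

- Compound 1 `CCNc1cc(-c2ccc(NC(=O)Nc3cccc(Cl)c3)cc2C)ccn1`: 16600 nM
- Compound 2 `CCNc1cc(-c2ccc(NC(=O)Nc3ccc(OC)cc3)cc2C)ccn1`: 25800 nM
- Compound 3 `CCNc1cc(-c2ccc(NC(=O)Nc3ccccc3Cl)cc2C)ccn1`: > 30000 nM (a limit of the assay, not a number)

In a functional assay on BT-483 cells (Homo sapiens) for cytotoxicity, read by MTT assay, with a stated time of 24 h (a lower number here means a stronger inhibitor, a higher number a weaker inhibitor), compound 2 gives 25800 nM. Only compound 1 offers a true number for comparison, with a 1.6-fold higher number from compound 1 to compound 2 (0.19 log units; within the scatter).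

Compound 4 `CCNc1cc(-c2ccc(NC(=O)Nc3ccc(OC)cc3)cc2C(F)(F)F)ccn1` keeps the rest of compound 2 but changes one group: trifluoromethyl in place of methyl on an aromatic carbon. The new trifluoromethyl sits on an aromatic carbon, ortho to a 2-(ethylamino)pyridin-4-yl group.

The measured steps offer only indirect guidance, as each of them changes the substituted phenyl on the amide-type nitrogen. Besides the step above, they are an at least 1.8-fold higher number from compound 1 to compound 3 (0.25 log units; that floor lies within the scatter) and an at least 1.1-fold higher number from compound 2 to compound 3 (0.06 log units; that floor lies within the scatter). Within the data shown here, no measured compound carries a change at the methyl position, so the size of this new step is unknown. As far as these compounds go, with no evidence for a larger shift, no step beyond the scatter is expected in this assay, and the direction stays open.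

The expected step is a 1.3-fold lower number from compound 2 to compound 4 (0.11 log units; within the scatter). Compound 4 is estimated at 20000 nM, with an expected range from 8000 nM to 40000 nM.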

Compound 4, half-maximal inhibitory concentration: 17600 nM
Compound 4: the middle estimate sits 1.1-fold (0.06 log units) above what was measured; low and high end bracket the measured number.
By their numbers in this assay, from the lowest: compounds 1, 4 and 2 (each within the scatter of the next). At a limit, above all of these: compound 3.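

Among the compounds shown, this is the only step at the methyl position; all the others change the phenyl group on the amide-type nitrogen. In this assay, trifluoromethyl in place of methyl gives a 1.5-fold lower number from compound 2 to compound 4 (0.17 log units; within the scatter), so this position, ortho to a 2-(ethylamino)pyridin-4-yl group, takes a group of more heavy atoms with no change beyond the scatter. Compound 3 alone stands at a limit of the assay rather than a number: the limit of > 30000 nM in this assay, at which 1 of the 4 values shown sits.

One replacement cannot show whether this position is generally insensitive, and an amine or a carboxylic acid in place of the methyl could behave quite differently. As far as these compounds go, it also stays open whether trifluoromethyl would give a similarly small step alongside the 3-chlorophenyl group of compound 1.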